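The source may report more compounds than this note shows. Statements on the series, on what has been measured and on what is new or still open speak of the compounds shown alone.

Results so far in an in vivo ADME assay on the whole organism (plasma, strain Sprague-Dawley) for pharmacokinetics, with Rattus norvegicus as the target, read by LC-MS; a lower number here means slower removal, a higher number faster removal of the compound:
- compound 1 `CCN1CCC(Oc2ccnc(C(=O)Nc3ccc(NC(=O)Nc4cc(C(C)(C)C)on4)cc3)c2)CC1` gives "not determined" (no result reported)
- compound 2 `CCN1CCC(Cc2ccc(C(=O)Nc3ccc(NC(=O)Nc4cc(C(C)(C)C)on4)cc3)nc2)CC1` gives 24 mL/min/kg
- compound 3 `CC(C)(C)c1cc(NC(=O)Nc2ccc(NC(=O)c3cc(OC4CCNCC4)ccn3)cc2)no1` gives 35.8 mL/min/kg

Compound 3 at 35.8 mL/min/kg and compound 2 at 24 mL/min/kg lie within the usual scatter of each other, so the two cannot be told apart. Compound 1 offers no number to set beside them.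

The account now turns to compound 4 `Cc1ccnc(C(=O)Nc2ccc(NC(=O)Nc3cc(C(C)(C)C)on3)cc2)c1` which has yet to be measured. It carries methyl in place of (piperidin-4-yl)oxy on an aromatic carbon, and the counted difference from compound 3 is methyl in place of (piperidin-4-yl)oxy on an aromatic carbon with the rest of the structure the same.

Among the measured compounds shown here, no two measured compounds differ in one place only, so the data give no direct guide to the size of this change. The expectation therefore rests on the two numbers at hand, and it is a loose one. Compound 4 is expected to land near compound 2 at 24 mL/min/kg with no shift beyond the scatter. The estimated change is a 1.6-fold lower number from compound 3 to compound 4 (0.21 log units; within the scatter) and this expected step stays within the scatter. For compound 4 the estimated value is 22 mL/min/kg with an expected range from 9 mL/min/kg to 50 mL/min/kg in this measurement.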

Compound 4, clearance: 37.9 mL/min/kg
Compound 4: the middle estimate sits 1.7-fold (0.24 log units) below what was measured, within the range that was stated.
By their numbers in this assay, from the lowest: compounds 2, 3 and 4 (each within the scatter of the next).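

In this assay, among the compounds shown here, the exchange of (piperidin-4-yl)oxy for methyl on the aromatic carbon opposite the ring nitrogen gives a 1.1-fold higher number from compound 3 to compound 4 (0.02 log units; within the scatter), the first step here that isolates a single structural change and one that stays within the scatter. At this place, then, a group of 7 heavy atoms with a six-membered non-aromatic ring, 1 hydrogen-bond donor and 2 hydrogen-bond acceptors cannot be told apart in this read-out from a group of 1 heavy atom with no ring, donor or acceptor, so for this pair the ring and its ether oxygen are not needed for a clearance of this size. Nothing available accounts for this lack of separation.

The compounds shown leave open whether any other group on this carbon, such as a carboxylic acid, a primary amine or a longer alkyl chain, would produce a step beyond the scatter. They also leave open whether a bare hydrogen there would behave as methyl does, and whether the same exchange would read alike on another aromatic carbon of this ring.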